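This account rests on a few compounds, and the source may have more. Where it says the series, first, only, none or still open, it means among the compounds named here.

Compound 1 `CSc1nc(NCc2ccc(-c3ccccn3)cc2)c2[nH]nc(C(C)C)c2n1`, compound 2 `CC(C)c1n[nH]c2c(NCc3ccc(-c4ccccn4)cc3)nc(SC(CO)C(C)C)nc12` and compound 3 `CC(C)c1n[nH]c2c(NCc3ccc(-c4ccccn4)cc3)nc(SCCCO)nc12` share one core and differ only in the group carried on the sulfur. In a functional assay on HT cells (Homo sapiens) for antiproliferative activity, read by fluorescence, with a stated time of 72 h (on this read-out higher numbers stand for weaker inhibition of growth and lower numbers for stronger inhibition of growth), compound 1 gives 783 nM, compound 2 gives 980 nM, and compound 3 gives 109 nM, the lowest of the three numbers. The step of a 1.3-fold higher number from compound 1 to compound 2 (0.10 log units; within the scatter) lies within the scatter, whereas a 7.2-fold lower number from compound 1 to compound 3 (0.86 log units; beyond the scatter) and a 9.0-fold lower number from compound 2 to compound 3 (0.95 log units; beyond the scatter) both go beyond it, so compound 3 stands apart from the other two on this assay. Compound 4 `CC(C)c1n[nH]c2c(NCc3ccc(-c4ccccn4)cc3)nc(SCCNC(N)=O)nc12` is derived from compound 3 by ureido in place of hydroxymethyl on a saturated chain carbon, two bonds along the chain from a sulfur. Among the compounds with values here, no measured step alters the end of the chain in this manner; the two steps that lead to compound 3 show only that the group on the sulfur can shift the number beyond the scatter, and they say nothing about a ureido group. The step of a 2.0-fold higher number from compound 3 to compound 4 (0.30 log units; within the scatter) is therefore expected to be modest, with its direction uncertain, and a wide range is attached to it. Compound 4 is estimated to give 220 nM in this assay, expected to fall between 60 nM and 800 nM.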

Compound 4, concentration for 50% growth inhibition: 240 nM
The estimate for compound 4 lay 1.1-fold (0.04 log units) below the measured number, and the stated range covers the measured number.
By their numbers in this assay, from the lowest: compound 3; then compound 4; then compounds 1 and 2 (each within the scatter of the next).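

In this assay the swap of hydroxymethyl for ureido on a saturated chain carbon, two bonds along the chain from a sulfur, gives a 2.2-fold higher number from compound 3 to compound 4 (0.34 log units; beyond the scatter) and so goes beyond the scatter, which shows that the number responds to the group at the end of this chain and not only to the size or branching of the whole group on the sulfur. The low numbers are also not confined to the 3-hydroxypropyl group, since the 2-ureidoethyl group still gives a 3.3-fold lower number from compound 1 to compound 4 (0.51 log units; beyond the scatter) and a 4.1-fold lower number from compound 2 to compound 4 (0.61 log units; beyond the scatter) while remaining behind compound 3, so among these four compounds the two unbranched chains with a polar-named end both stand below methyl, and compound 2, which also carries a hydroxyl but on a branched group, goes against any rule based on the hydroxyl alone. Nothing available here accounts for these differences.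

What the compounds leave open is whether an amine or a carboxylic acid at the end of the chain would give a number nearer that of compound 3 or that of compound 1. Also open, on these data alone, is how a longer chain would behave, since the step from 3-hydroxypropyl to 2-ureidoethyl changes the end group and the carbon chain together, and a 3-ureidopropyl group would separate the two.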